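Saturated Amine Swap on a Fluorinated Pyrimidine-Bearing Core

The compounds below may be only part of what the source reports. "The series", "measured", "known", "first", "only" and "open" are said of these compounds alone.

Compound 1 `Fc1ccccc1Cn1nc(-c2ncc(F)c(OCC3CC3)n2)cc1-c1ccon1`: 450 uL/min
Compound 2 `Fc1ccccc1Cn1nc(-c2ncc(F)c(N3CCCC3)n2)cc1-c1ccon1`: 500 uL/min

Of the compounds shown here, two have so far been measured in an ADME assay on microsomes from liver (Rattus norvegicus) for pharmacokinetics; on this read-out higher numbers stand for fast clearance and lower numbers for slow clearance. Compound 1 gives 450 uL/min in this assay, and compound 2 gives 500 uL/min. For the measured compounds named here, the only measured step, a 1.1-fold higher number from compound 1 to compound 2 (0.05 log units; within the scatter), is within the scatter, so the two numbers cannot be told apart; compound 2 simply sits alongside compound 1.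

The next step leads from compound 2 to compound 3 `Fc1ccccc1Cn1nc(-c2ncc(F)c(N3CCC(F)(F)CC3)n2)cc1-c1ccon1`. The change is 4,4-difluoropiperidin-1-yl in place of pyrrolidin-1-yl on an aromatic carbon.

Going by the values given here, no measured pair matches this change directly. Among the compounds with values here, the one step on record, a 1.1-fold higher number from compound 1 to compound 2 (0.05 log units; within the scatter), shows that exchanging the group at this position of the core moved the number by no more than the scatter. On that basis the exchange of pyrrolidin-1-yl for 4,4-difluoropiperidin-1-yl is expected to give a step in this assay of no more than the scatter, with no clear direction. Compound 3 is therefore estimated at 420 uL/min, with a range from 200 uL/min to 850 uL/min, meaning an expected step of a 1.2-fold lower number from compound 2 to compound 3 (0.08 log units; within the scatter).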

Compound 3, intrinsic clearance in a liver preparation (reported as CLH), per the amount of preparation that the assay uses: 340 uL/min
Compound 3: the middle estimate sits 1.2-fold (0.09 log units) above what was measured, and the stated range covers the measured number.
By their numbers in this assay, from the lowest: compounds 3, 1 and 2 (each within the scatter of the next).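

In this assay, the exchange of pyrrolidin-1-yl for 4,4-difluoropiperidin-1-yl gives a 1.5-fold lower number from compound 2 to compound 3 (0.17 log units; within the scatter), and the exchange of cyclopropylmethoxy for the same group gives a 1.3-fold lower number from compound 1 to compound 3 (0.12 log units; within the scatter). This extends the earlier reading from one exchange to three groups: a six-membered ring with two fluorines, with 8 heavy atoms in place of 5, cannot be told apart from the five-membered pyrrolidin-1-yl or from cyclopropylmethoxy at this aromatic carbon, and none of the three compounds goes against that. The compounds shown offer no measurement that would explain why the numbers stay so close.

Going by these compounds, it remains open whether any group at this position can move the number beyond the scatter, for example an open-chain amine such as dimethylamino, a morpholine ring or a carboxylic acid. On these data alone, it is also open whether the number responds to a change elsewhere on the shared core, since all three compounds differ only at this one place.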